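Series notes: aryl amide ester set, cytotoxicity, step to compound 4

A few compounds are considered here, and "the series" means these few. Any claim that something is new, unique, unknown or untested is made for them only; others in the source may bear on it.

Measured compounds:
- Compound 1, `CCOC(=O)CCCCCOc1cccc(CN(C(=O)c2ccc(-c3cccc(NC(C)=O)c3)cc2)C(C)C)c1`: in an ADME assay on HEK293 cells (Homo sapiens) for cytotoxicity, read by CellTiter-Glo and resazurin assay, with a stated time of 72 h (a lower number here means that less compound is needed, a higher number that more compound is needed for the effect), compound 1 gives > 26000 nM, which is a limit of the assay and not a number.
- Compound 2, `CCOC(=O)CCCCCOc1cccc(CN(C(=O)c2ccc(-c3ccc(C(C)=O)s3)cc2)C(C)C)c1`: in this assay compound 2 gives > 26000 nM, again a limit.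
- Compound 3, `CCOC(=O)CCCCCOc1cccc(CN(C(=O)c2ccc(-c3cccc(OCc4ccccc4)c3)cc2)C(C)C)c1`: in this assay compound 3 gives > 26000 nM, also a limit.

Compound 3 therefore stands at the same limit as the other two; no ordering among compounds 1, 2 and 3 can be read, because all three sit on (the limit of > 26000 nM in this assay, at which 3 of the 3 values shown sit). The steps a step that the two limits leave unreadable from compound 1 to compound 2 and a step that the two limits leave unreadable from compound 1 to compound 3 are both unreadable for that reason, so the measured steps give no size in either direction.

Compound 4, `CCOC(=O)CCCCCOc1cccc(CN(C(=O)c2ccc(-c3cccc(-c4nnc(C)o4)c3)cc2)C(C)C)c1`, differs from compound 3 by 5-methyl-1,3,4-oxadiazol-2-yl in place of benzyloxy on an aromatic carbon. Going by the values given here, since no measured step in this assay is readable, the expectation for compound 4 rests only on the fact that every value shown sits on (the limit of > 26000 nM in this assay, at which 3 of the 3 values shown sit). The step that the limit leaves unreadable from compound 3 to compound 4 is expected to be none beyond the scatter, and compound 4 is most likely to return a limit as well. The estimate for compound 4 in this assay is 40000 nM, within the range 15000 nM to 150000 nM.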

Compound 4, half-maximal effective concentration: > 26000 nM
Compound 4: only a limit was reported; the forecaster's own chance of this, stated with the estimate: 80%; the middle value is on the limit's open side.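

In this assay compound 4 gives > 26000 nM, a limit of the assay and not a number. No step between compound 4 and compounds 1, 2 or 3 can be read: the limit of > 26000 nM in this assay, at which 4 of the 4 values shown sit.

The compounds shown leave open whether any of compounds 1 to 4 reaches a half-maximal effect in this assay, and whether their substituents differ at all there.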